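The source may hold more compounds than are shown below. What is called first, only, known or untested is meant among the compounds shown, and "the series" means these compounds.

Of the compounds shown here, three built on a shared core have been tested in a functional assay on HCT-116 cells (Homo sapiens) for antiproliferative activity, read by MTT assay, with a stated time of 48 h; on this read-out higher numbers stand for weaker inhibition of growth and lower numbers for stronger inhibition of growth. Compound 1 `Cc1ccc(-c2cnc(N(Cc3ccccc3)Cc3ccc(C(=O)NO)cc3)s2)cc1` gives 48800 nM, compound 2 `CCCCCCCCN(Cc1ccc(C(=O)NO)cc1)c1ncc(-c2ccc(C)cc2)s1` gives 6500 nM, and compound 3 `Cc1ccc(-c2cnc(N(Cc3ccc(C(=O)NO)cc3)C(C)C)s2)cc1` gives 7800 nM. Compound 2 has the lowest number of the three, though its gap to compound 3 lies within the scatter. Compound 4 `CCCN(Cc1ccc(C(=O)NO)cc1)c1ncc(-c2ccc(C)cc2)s1` differs from compound 2 by hydrogen in place of pentyl on a saturated chain carbon, three bonds along the chain from a nitrogen on an aromatic ring. The comparison that bears most directly on this is a 1.2-fold higher number from compound 2 to compound 3 (0.08 log units; within the scatter), where isopropyl stood in for octyl with no effect beyond the scatter. The larger moves, a 7.5-fold lower number from compound 1 to compound 2 (0.88 log units; beyond the scatter) and a 6.3-fold lower number from compound 1 to compound 3 (0.80 log units; beyond the scatter), both involved replacing benzyl with an alkyl group, which is not what changes here. The expected step is therefore a 1.2-fold higher number from compound 2 to compound 4 (0.06 log units; within the scatter), within the scatter. Compound 4 is estimated at 7500 nM, with a likely range from 3500 nM to 16000 nM.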

Compound 4, concentration for 50% growth inhibition: 5800 nM
Estimate against measurement, compound 4: 1.3-fold (0.11 log units) above; measured number inside the range.
By their numbers in this assay, from the lowest: compounds 4, 2 and 3 (each within the scatter of the next); then compound 1.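

Shortening the octyl chain to propyl does not shift the number beyond the scatter (a 1.1-fold lower number from compound 2 to compound 4 (0.05 log units; within the scatter)), so at this position the pentyl portion can go without a measurable loss of growth inhibition. Straight propyl and branched isopropyl also cannot be told apart (a 1.3-fold lower number from compound 3 to compound 4 (0.13 log units; within the scatter)), while the gain over benzyl-bearing compound 1 holds for the short chain too (an 8.4-fold lower number from compound 1 to compound 4 (0.92 log units; beyond the scatter)). No measurement shown here explains these results. Going by these compounds, whether a chain ending in an amine or a carboxylic acid would match these plain alkyl chains remains open, as does the effect of a methyl group on this nitrogen.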